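The source may report more compounds than this note shows. Statements on the series, on what has been measured and on what is new or still open speak of the compounds shown alone.

Measured so far:
compound 1, `Cc1ccc2oc(SCC(=O)Nc3ccc(-c4nc(-c5ccccc5)c(-c5ccccc5)n4C)cc3)nc2c1`, 57.7%
compound 2, `Cn1cnnc1SCC(=O)Nc1ccc(-c2nc(-c3ccccc3)c(-c3ccccc3)n2C)cc1`, 89.2%

In a functional assay on MCF7 cells (Homo sapiens) for cytotoxicity, read by MTT assay, with a stated time of 24 h, tested at 32 ug/mL (a lower number here means a weaker effect, a higher number a stronger effect of the compound at the concentration tested), compound 2 stands highest of the two numbers; the nearest is compound 1, and the step of a number 31.5 percentage points higher from compound 1 to compound 2 (beyond the scatter) lies beyond the scatter. Compound 3, `Cn1nnnc1SCC(=O)Nc1ccc(-c2nc(-c3ccccc3)c(-c3ccccc3)n2C)cc1`, is not yet measured. It differs from compound 2 in one place: 1-methyl-1H-tetrazol-5-yl in place of 4-methyl-4H-1,2,4-triazol-3-yl on a sulfur. Among the measured compounds shown here, the only measured step, a number 31.5 percentage points higher from compound 1 to compound 2 (beyond the scatter), also exchanges one group on that sulfur for another and was large, but neither of its groups is the one that enters here, so it gives no direct read on the step from compound 2 to compound 3. The group that leaves and the group that enters are each one five-membered aromatic ring, differing in the count of hetero atoms, and the compounds otherwise match. With nothing in the data pointing either way, no step beyond the scatter is expected in this assay. The step expected is a number 5.2 percentage points lower from compound 2 to compound 3 (within the scatter), kept within the scatter and leaning slightly lower only because compound 2 sits at 89.2%, near the top of the range seen. Compound 3 is therefore estimated at 84% in this assay, with a range from 62% to 96%.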

Compound 3, a percentage reported as activity, at one concentration (the size of the read-out at that concentration, not a potency): 77.5%
For compound 3 the middle estimate is 6.5 percentage points above the measured one; low and high end bracket the measured number.
By their numbers in this assay, from the lowest: compound 1; then compound 3; then compound 2.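

In this assay, 1-methyl-1H-tetrazol-5-yl in place of 4-methyl-4H-1,2,4-triazol-3-yl on the sulfur gives a number 11.7 percentage points lower from compound 2 to compound 3 (beyond the scatter), so two groups that are each one five-membered aromatic ring, and differ in their count of hetero atoms, are not interchangeable at this position. Against 5-methyl-1,3-benzoxazol-2-yl, the tetrazolyl group gives a number 19.8 percentage points higher from compound 1 to compound 3 (beyond the scatter), so both groups consisting of one five-membered aromatic ring now read higher than that group, with compound 2 still at the top of the three. The sulfur position therefore separates even closely matched rings, and not only groups as different as the first pair, although three compounds are too few to establish a trend with the count of hetero atoms.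

No data at hand bear on what lies behind these differences. Going by these compounds, it remains open how a non-aromatic group on the same sulfur, such as a simple amine-bearing chain or a carboxylic acid, would read, and whether an ethyl group in place of the ring methyl would keep the number of compound 2 or compound 3.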